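This account rests on a few compounds, and the source may have more. Where it says the series, first, only, none or still open, it means among the compounds named here.

In an ADME assay on microsomes from liver (Rattus norvegicus, strain Sprague-Dawley) for metabolic stability, read by LC-MS, with a stated time of 15 min, tested at 20 uM (on this read-out higher numbers stand for a more stable compound and lower numbers for a less stable compound), compound 1 (`Cc1ccn2c(C(=O)NCc3ccc(Cl)cc3)c(C)nc2c1`) reads 80.7% and compound 2 (`CCC(=O)c1ccccc1OC(=O)c1coc(-c2ccccc2)n1`) reads 8.7% as the lower of the two numbers, a gap beyond the scatter. Compound 3 (`CCC(C)c1ccccc1OC(=O)c1coc(-c2ccccc2)n1`) is unmeasured and carries sec-butyl in place of propanoyl on an aromatic carbon, ortho to a large group (sec-butyl in place of propanoyl on an aromatic carbon). Among the compounds with values here, no measured step covers this change, so the expectation rests on compound 2 at 8.7% alone. The expected result in this assay is no shift beyond the scatter, an estimated a number 3.3 percentage points higher from compound 2 to compound 3 (within the scatter) in this series. For compound 3 the estimate is 12% with an expected range from 3% to 28% for the coming measurement.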

Compound 3, percent of the compound remaining: 8.3%
The estimate for compound 3 lay 3.7 percentage points above the measured number; low and high end bracket the measured number.
By their numbers in this assay, from the lowest: compounds 3 and 2 (each within the scatter of the next); then compound 1.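

In this assay the exchange of propanoyl for sec-butyl on an aromatic carbon, ortho to a large group, gives a number 0.4 percentage points lower from compound 2 to compound 3 (within the scatter) and shows that this position tolerates the loss of the double bond outside aromatic rings and of the hydrogen-bond acceptor without a shift beyond the scatter. Nothing available explains why the read-out holds across this change. Still open, going by these compounds, is whether an amine, a carboxylic acid or a longer chain on this aromatic carbon would move the percent remaining beyond the scatter.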